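Chlorine on the Benzyl Ring: Expected Cell Tolerance

The compounds below may be only part of what the source reports. "The series", "measured", "known", "first", "only" and "open" are said of these compounds alone.

Compound 1 `Cc1ccc(-c2nn(-c3ccccc3)cc2C(=O)NOCc2ccccc2Cl)cc1`: 38700 nM
Compound 2 `COc1ccc(-c2nn(-c3ccccc3)cc2C(=O)NOCc2ccccc2Cl)cc1`: 586000 nM
Compound 3 `O=C(NOCc1ccccc1)c1cn(-c2ccccc2)nc1-c1ccc(F)cc1`: 217000 nM

In an ADME assay on HEK-293T cells (Homo sapiens) for antiproliferative activity, read by MTT assay, with a stated time of 48 h, in the presence of a further agent that is not named here (a higher number here means that more compound is tolerated, a lower number that less compound is tolerated), compound 3 stands second highest of the three numbers; its nearest neighbour is compound 2, and compound 1 lies furthest away, at the low end. Compound 4 `O=C(NOCc1ccccc1Cl)c1cn(-c2ccccc2)nc1-c1ccc(F)cc1` differs from compound 3 by chloro in place of hydrogen on an aromatic carbon. For the measured compounds named here, the only measured step, a 15-fold higher number from compound 1 to compound 2 (1.18 log units; beyond the scatter), concerns a different place on the molecule and so does not bear on this change. Going by the values given here, compounds 1 and 2 both carry the 2-chlorobenzyl group, yet their numbers lie far apart, and no measured pair differs only by this chlorine. With nothing to point either way, the step expected is a 1.1-fold lower number from compound 3 to compound 4 (0.04 log units; within the scatter), nothing beyond the scatter, held with wide uncertainty. For compound 4 the estimate in this assay is 200000 nM, ranging from 60000 nM to 700000 nM.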

Compound 4, half-maximal cytotoxic concentration: 44700 nM
Compound 4: middle estimate off by 4.5-fold (0.65 log units), on the high side, outside the stated range (below it).
By their numbers in this assay, from the lowest: compounds 1 and 4 (each within the scatter of the next); then compound 3; then compound 2.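

In this assay, for the compounds shown here, the chloro group on the benzyl ring, ortho to a large group, brings a 4.9-fold lower number from compound 3 to compound 4 (0.69 log units; beyond the scatter) and gives the first direct reading of this change. With the 2-chlorobenzyl group kept, fluoro in place of methoxy gives a 13-fold lower number from compound 2 to compound 4 (1.12 log units; beyond the scatter) while fluoro in place of methyl gives a 1.2-fold higher number from compound 1 to compound 4 (0.06 log units; within the scatter) and so leaves no clear change. No measurement here explains these steps. Open, on these data alone, is whether an amine or a carboxylic acid on the benzyl ring would move the number as chloro does. Also open, as far as these compounds go, is whether the chloro step keeps its size with methyl or methoxy in place of fluoro.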